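Changing the amide aryl group of compound 1

The source may report more compounds than this note shows. Statements on the series, on what has been measured and on what is new or still open speak of the compounds shown alone.

For the measured compounds named here, in a functional assay on CCRF-CEM cells (Homo sapiens) for cytotoxicity (a higher number here means a weaker inhibitor, a lower number a stronger inhibitor), compound 1 (`COc1ccc(NC(=O)/C=C/C(=O)N2C/C(=C\c3ccc([N+](=O)[O-])cc3)C(=O)/C(=C/c3ccc([N+](=O)[O-])cc3)C2)cc1`) gives 760 nM as the higher of the two numbers so far. Compound 2 (`O=C(/C=C/C(=O)N1C/C(=C\c2ccccc2)C(=O)/C(=C/c2ccccc2)C1)Nc1ccc(Cl)c(Cl)c1`) gives 350 nM and the gap between them lies beyond the usual scatter. Compound 1 and compound 2 differ in more than one place, so no single structural change can be read from that gap. Compound 3 (`Cc1ccc(NC(=O)/C=C/C(=O)N2C/C(=C\c3ccc([N+](=O)[O-])cc3)C(=O)/C(=C/c3ccc([N+](=O)[O-])cc3)C2)cc1C`) keeps the core of compound 1 and carries 3,4-dimethylphenyl in place of 4-methoxyphenyl on an amide-type nitrogen. Going by the values given here, no measured step covers this exchange. A small move towards a lower number in this assay is expected, quite possibly none beyond the scatter. The expected move (a 1.4-fold lower number from compound 1 to compound 3 (0.14 log units; within the scatter)) stays modest. Compound 3 is estimated at 550 nM with 200 nM to 1500 nM as the expected range.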

Compound 3, half-maximal inhibitory concentration: 700 nM
Compound 3: the middle estimate sits 1.3-fold (0.10 log units) below what was measured; the measured number falls inside the stated range.
By their numbers in this assay, from the lowest: compounds 2, 3 and 1 (each within the scatter of the next, the first and the last beyond it).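

In this assay, for the compounds shown here, the exchange of 4-methoxyphenyl for 3,4-dimethylphenyl on the amide-type nitrogen gives a 1.1-fold lower number from compound 1 to compound 3 (0.04 log units; within the scatter), the first step that can be read at a single place, with the core of compound 1 held fixed. The hydrogen-bond acceptor counted on 4-methoxyphenyl is absent from 3,4-dimethylphenyl, yet the two compounds stay within the scatter of each other, so in this pair that acceptor is not required for this level of cytotoxicity. Nothing measured on hand explains this result.

Still open, going by these compounds, is whether an aminophenyl or carboxyphenyl group, or a longer alkyl chain, on this nitrogen would separate from these two aryl groups. The same exchange on the core of compound 2 also remains to be read.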